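The source may hold more compounds than are shown below. What is called first, only, known or untested is meant among the compounds shown, and "the series" means these compounds.

Of the compounds shown here, two on one shared core have so far been measured in a functional assay on P388 cells (Mus musculus) for cytotoxicity; a lower number here means a stronger inhibitor, a higher number a weaker inhibitor. Compound 1 `C=Cc1ccc(C[C@H]2C(=O)N[C@@H](C)C(=O)N(C)[C@H]3Cc4ccc(cc4)Oc4cc(ccc4OC)C[C@@H](C(=O)N[C@H](C)C(=O)N[C@@H](C)C(=O)N2C)N(C)C3=O)cc1` gives 17 nM, while compound 2 `C/C=C/c1ccc(C[C@H]2C(=O)N[C@@H](C)C(=O)N(C)[C@H]3Cc4ccc(cc4)Oc4cc(ccc4OC)C[C@@H](C(=O)N[C@H](C)C(=O)N[C@@H](C)C(=O)N2C)N(C)C3=O)cc1` gives 5.01 nM, the lower of the two numbers, which makes compound 2 the stronger inhibitor of the pair. The next case is compound 3 `CCCc1ccc(C[C@H]2C(=O)N[C@@H](C)C(=O)N(C)[C@H]3Cc4ccc(cc4)Oc4cc(ccc4OC)C[C@@H](C(=O)N[C@H](C)C(=O)N[C@@H](C)C(=O)N2C)N(C)C3=O)cc1`, which differs from compound 2 as follows: propyl in place of prop-1-en-1-yl on an aromatic carbon. In plain terms, it carries propyl in place of prop-1-en-1-yl on an aromatic carbon. For the measured compounds named here, only one measured step bears on this change, a 3.4-fold lower number from compound 1 to compound 2 (0.53 log units; beyond the scatter). Going by the values given here, that step was modest and beyond the scatter, but it exchanged vinyl for prop-1-en-1-yl, so it is only a rough guide to size, and no measurement yet shows the effect of exchanging prop-1-en-1-yl for propyl. Among the compounds with values here, a shift no larger than that step is therefore expected in this assay, probably towards a slightly higher number and possibly within the scatter. The expected change is a 1.6-fold higher number from compound 2 to compound 3 (0.20 log units; within the scatter). For compound 3 the estimated value is 8 nM, with an expected range from 2.5 nM to 25 nM.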

Compound 3, half-maximal inhibitory concentration: 25.7 nM
Estimate against measurement, compound 3: 3.2-fold (0.51 log units) below; measured number above the stated range.
By their numbers in this assay, from the lowest: compound 2; then compounds 1 and 3 (each within the scatter of the next).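

Compound 3 keeps the three carbons of prop-1-en-1-yl and loses only the double bond outside the aromatic ring, yet in this assay this single change gives a 5.1-fold higher number from compound 2 to compound 3 (0.71 log units; beyond the scatter), so at this place, para to a large group, the carbon count of the chain does not alone set the number. Set against vinyl, propyl gives a 1.5-fold higher number from compound 1 to compound 3 (0.18 log units; within the scatter), which means that the lower number reached with prop-1-en-1-yl does not follow from a three-carbon chain as such and, among these three compounds, is seen only where chain length and the double bond occur together. No measured evidence is available to explain why the double bond matters here.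

The compounds shown leave open whether the double bond must sit where it does in prop-1-en-1-yl, since neither prop-2-en-1-yl nor the other geometric isomer of prop-1-en-1-yl appears among them. They also leave open how ethyl, a longer chain such as butyl or a longer alkenyl chain, or a chain ending in an amine or a carboxylic acid would read at this place.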